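This account rests on a few compounds, and the source may have more. Where it says the series, first, only, none or still open, it means among the compounds named here.

Measured compounds:
compound 1, `CCc1nc2ccccc2n1CCCCOc1ccccc1`, 21 uM
compound 2, `CCc1nc2ccccc2n1CCCCOc1cccc(Cl)c1`, 22 uM
compound 3, `CCc1nc2ccc(C)cc2n1CCCOc1ccc(C)c(Cl)c1`, 17 uM

In an ADME assay on Vero cells (Chlorocebus sabaeus) for cytotoxicity, read by luminescence, with a stated time of 2 days (on this read-out lower numbers stand for higher toxicity in this test and higher numbers for lower toxicity in this test), compound 1 gives 21 uM, compound 2 gives 22 uM and compound 3 gives 17 uM. Compound 1 and compound 2 differ in one place, (hydrogen in place of chloro on an aromatic carbon), and the step is a 1.0-fold lower number from compound 2 to compound 1 (0.02 log units; within the scatter). Compound 3 shares the same kind of core, but the difference between the cores of compound 2 and compound 3 is not broken down here; the two values lie within the usual scatter of each other.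

The unmeasured compound 4, `CCc1nc2ccc(C)cc2n1CCCOc1ccc(C)cc1`, relates to compound 3 as compound 1 relates to compound 2: hydrogen in place of chloro on an aromatic carbon. The place is not identical, since in compound 3 the chloro sits ortho to a methyl group as well as meta to a large group, so this is the same kind of change rather than the same one. Because the earlier step was a 1.0-fold lower number from compound 2 to compound 1 (0.02 log units; within the scatter), compound 4 is expected to land close to compound 3, an estimated step of a 1.1-fold higher number from compound 3 to compound 4 (0.02 log units; within the scatter) in this assay. Compound 4 is therefore estimated at 18 uM, with a range from 9 uM to 36 uM.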

Compound 4, half-maximal toxic concentration: 15 uM
Estimate against measurement, compound 4: 1.2-fold (0.08 log units) above; measured number inside the range.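

In this assay, exchanging chloro for hydrogen, which turns the 3-chloro-4-methylphenyl group into the 4-methylphenyl group, gives a step of a 1.1-fold lower number from compound 3 to compound 4 (0.05 log units; within the scatter). Set beside the earlier step, the same kind of change carries over between these two cores without a detectable difference: the same change on two cores in this assay, a 1.0-fold lower number (0.02 log units; within the scatter) from compound 2 to compound 1 and a 1.1-fold lower number (0.05 log units; within the scatter) from compound 3 to compound 4, 1.1-fold (0.03 log units) apart, within the scatter of two such steps. Among these compounds, this shows only that neither pair moves the read-out beyond the scatter; it rests on two pairs with the chloro in different places, and it does not show that the change would behave this way on any other core or in any other test.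

The compounds shown leave open whether a fluoro group, a methoxy group or a carboxylic acid in place of the chloro would give a step beyond the scatter in this assay. On these data alone, it also remains open whether an amine on the aromatic ring or a longer chain between the shared core and the oxygen would do so.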